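The compounds below may be only part of what the source reports. "The series", "measured", "known", "first", "only" and "open" are said of these compounds alone.

Two measured compounds share a core. Compound 1 `CN(C)CCNc1nc(-c2ccc(NC(=O)Nc3ccc(Cl)cc3)cc2)nc2ccsc12` gives 310 nM in a functional assay on MDA-MB-231 cells (Homo sapiens) for cytotoxicity, read by MTT assay, with a stated time of 72 h (on this read-out higher numbers stand for weaker inhibition and lower numbers for stronger inhibition), and compound 2 `CCN(CC)CCNc1nc(-c2ccc(NC(=O)Nc3ccccc3F)cc2)nc2ccsc12` gives 580 nM in this assay. Compound 2 holds the highest of these two numbers, though its gap to compound 1 lies within the scatter, so no order between them can be claimed.

Compound 3 `CCN(CC)CCNc1nc(-c2ccc(NC(=O)Nc3ccc(Cl)cc3)cc2)nc2ccsc12` is not yet measured. It differs from compound 2 by one change: 4-chlorophenyl in place of 2-fluorophenyl on an amide-type nitrogen. Going by the values given here, no measured pair shows this change on its own, so the expected step of a 1.5-fold lower number from compound 2 to compound 3 (0.16 log units; within the scatter) is small and may stay within the scatter. Compound 3 is expected to give about 400 nM in this assay, within 180 nM to 900 nM.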

Compound 3, half-maximal inhibitory concentration: 550 nM
Estimate against measurement, compound 3: 1.4-fold (0.14 log units) below; measured number inside the range.
By their numbers in this assay, from the lowest: compounds 1, 3 and 2 (each within the scatter of the next).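

In this assay, the exchange of 2-fluorophenyl for 4-chlorophenyl on the amide-type nitrogen gives a 1.1-fold lower number from compound 2 to compound 3 (0.02 log units; within the scatter), so this swap between halogen-bearing phenyl groups has no readable effect here. Diethylamino in place of dimethylamino on the chain gives a 1.8-fold higher number from compound 1 to compound 3 (0.25 log units; within the scatter), so this change at the chain end cannot be read either. No supporting evidence bears on these results. Still open, on these data alone, is whether cyclohexyl on the amide-type nitrogen, or dipropylamino in place of diethylamino, would move the number beyond the scatter.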